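A few compounds are considered here, and "the series" means these few. Any claim that something is new, unique, unknown or untested is made for them only; others in the source may bear on it.

Measured compounds:
Compound 1 `Cc1ccc(-n2nncc2CN2C(=O)C3(C(C#N)=C(N)Oc4c3c3nc5ccccc5nc3c3ccccc43)c3ccccc32)cc1Cl` — in an ADME assay on L02 cells (Homo sapiens) for antiproliferative activity, read by MTT assay, with a stated time of 48 h (on this read-out lower numbers stand for stronger inhibition and higher numbers for weaker inhibition), compound 1 gives > 50000 nM, a limit of the assay.
Compound 2 `N#CC1=C(N)Oc2c(c3nc4ccccc4nc3c3ccccc23)C12C(=O)N(Cc1cnnn1-c1ccc(Cl)c(Cl)c1)c1ccccc12` — in this assay compound 2 gives > 50000 nM, a limit of the assay.
Compound 3 `N#CC1=C(N)Oc2c(N)cc3nc4ccccc4nc3c2C12C(=O)N(Cc1cnnn1-c1ccc(Cl)cc1)c1ccccc12` — in this assay compound 3 gives > 50000 nM, a limit of the assay.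

Compound 3 thus stands only at a limit in this assay, and it shares that position with every other value in the set, since (the limit of > 50000 nM in this assay, at which 3 of the 3 values shown sit). Going by the values given here, the one step between measured compounds that differ in one place, a step that the two limits leave unreadable from compound 1 to compound 2, is not readable because both ends sit at the limit, so no measured step gives a usable size or direction.

Compound 4 `N#CC1=C(N)Oc2c(N)cc3nc4ccccc4nc3c2C12C(=O)N(Cc1cnnn1-c1ccc([N+](=O)[O-])cc1[N+](=O)[O-])c1ccccc12` differs from compound 3 by 2,4-dinitrophenyl in place of 4-chlorophenyl on an aromatic nitrogen. Among the compounds with values here, no measured step bears on this exchange; nothing in the set shows a move away from the limit for any change on that aromatic nitrogen.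

Compound 4 is therefore expected to remain at the limit in this assay, with an estimate of 50000 nM between 20000 nM and 100000 nM. The expected step of a number no higher from compound 3 to compound 4 (the limit leaves the size open) is none beyond the scatter.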

Compound 4, half-maximal inhibitory concentration: 22800 nM
Beside the measured number, compound 4's estimate is 2.2-fold (0.34 log units) above it, within the range that was stated.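

In this assay, 2,4-dinitrophenyl in place of 4-chlorophenyl on the aromatic nitrogen gives an at least 2.1-fold lower number from compound 3 to compound 4 (0.34 log units; beyond the scatter), so a change at this position can bring the read-out off the limit. The size of this step is only a minimum, as its starting point is a limit and not a number. Compound 4, at 22800 nM, is the only compound shown with a measured number rather than a limit: the limit of > 50000 nM in this assay, at which 3 of the 4 values shown sit.

On these data alone, it remains open whether a single nitro group on the phenyl ring would give a similar step, or whether an amine or a carboxylic acid there would also move the number. As far as these compounds go, it is also open whether 2,4-dinitrophenyl would have the same effect on the core of compound 1.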